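The source may report more compounds than this note shows. Statements on the series, on what has been measured and on what is new or still open speak of the compounds shown alone.

Measured in a functional assay on T98G cells (Homo sapiens) for inhibition, read by colorimetric assay and MTT assay, with a stated time of 72 h; a higher number here means a weaker inhibitor, a lower number a stronger inhibitor:
Compound 1 `CCCCCCOc1ncc(-c2ccccc2OC)n1C` gives 58000 nM
Compound 2 `COc1ccccc1-c1cnc(OC)n1C` gives > 100000 nM as a limit

Compound 2 stands at the limit of > 100000 nM in this assay, at which 1 of the 2 values shown sits, and so has a limit rather than a number. Compound 3 `C=CCCOc1ncc(-c2ccccc2OC)n1C` differs from compound 2 by allyl in place of hydrogen on a saturated chain carbon bound to an oxygen on an aromatic ring, turning methoxy into (but-3-en-1-yl)oxy. Among the measured compounds shown here, one measured step bears on this: an at least 1.7-fold higher number from compound 1 to compound 2 (0.23 log units; that floor lies within the scatter), where hydrogen replaces pentyl, the opposite kind of change, and its floor stays within the scatter. A small move to a lower number is therefore expected, perhaps none beyond the scatter. The expected move is an at least 1.2-fold lower number from compound 2 to compound 3 (0.09 log units; that floor lies within the scatter) in this estimate. Compound 3 is estimated at 80000 nM with a range of 45000 nM to 140000 nM in this assay.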

Compound 3, half-maximal inhibitory concentration: 39000 nM
The estimate for compound 3 lay 2.1-fold (0.31 log units) above the measured number; measured number outside the range, below it.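

In this assay, allyl in place of hydrogen on this saturated chain carbon gives an at least 2.5-fold lower number from compound 2 to compound 3 (0.40 log units; beyond the scatter), so a change at this position now reaches beyond the scatter, which the earlier step did not. That size is only a floor, and compound 2 has a limit rather than a number: the limit of > 100000 nM in this assay, at which 1 of the 3 values shown sits. Vinyl in place of butyl further along the chain gives a 1.5-fold lower number from compound 1 to compound 3 (0.17 log units; within the scatter), which lies within the scatter, so these two chains are not told apart.

Open, as far as these compounds go, is whether a longer chain, or an amine or carboxylic acid at the chain end, would move the number further.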